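Cytotoxicity notes on a chromone series with a fluoro-for-methoxy step

A few compounds are considered here, and "the series" means these few. Any claim that something is new, unique, unknown or untested is made for them only; others in the source may bear on it.

Measured compounds:
compound 1 `COc1ccc(-c2cc(=O)c3cc(NC(C)=O)ccc3o2)cc1` — 226000 nM
compound 2 `CC(=O)Nc1ccc2oc(-c3ccc(F)cc3)cc(=O)c2c1` — 203000 nM
compound 3 `COc1ccccc1-c1oc2ccc(N)cc2c(=O)c1OC` — 229000 nM

All three numbers come from an ADME assay on MT4 cells (Homo sapiens) for cytotoxicity, read by MTT assay, with a stated time of 4 days; on this read-out higher numbers stand for lower toxicity in this test and lower numbers for higher toxicity in this test. In this assay compound 1 gives 226000 nM and compound 2 gives 203000 nM; the step between them is a 1.1-fold lower number from compound 1 to compound 2 (0.05 log units; within the scatter), so the two cannot be told apart here. The change that separates them is fluoro in place of methoxy on an aromatic carbon. Compound 3 gives 229000 nM, which lies within the scatter of both other values. How the core of compound 3 differs from the core of compound 1 is not broken down here.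

Compound 4 `COc1c(-c2ccccc2F)oc2ccc(N)cc2c1=O` has not been measured. It differs from compound 3 by fluoro in place of methoxy on an aromatic carbon. Among the compounds with values here, this is the same kind of change as the one from compound 1 to compound 2, not the same: in compound 2 the fluoro sits para to a large group, whereas in compound 4 it sits ortho to a large group, and the cores carrying it are not the same.

Expectation for compound 4: the only precedent for this kind of change is the step of a 1.1-fold lower number from compound 1 to compound 2 (0.05 log units; within the scatter), which stays within the scatter, and because compound 3 gives 229000 nM a step of about a 1.1-fold lower number from compound 3 to compound 4 (0.04 log units; within the scatter) is expected, leaving the number near its parent. Compound 4 is therefore estimated at 210000 nM, with a plausible range from 120000 nM to 350000 nM. Values this high may also be reported only as a limit of the assay.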

Compound 4, half-maximal cytotoxic concentration: 234000 nM
Estimate against measurement, compound 4: 1.1-fold (0.05 log units) below; low and high end bracket the measured number.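

Fluoro in place of methoxy on an aromatic carbon, here ortho to a large group, gives in this assay a step of a 1.0-fold higher number from compound 3 to compound 4 (0.01 log units; within the scatter), so compound 3 and compound 4 cannot be told apart. Set beside the earlier step, the change reads alike on the two cores, with no difference between them beyond the scatter: the same change on two cores in this assay, a 1.1-fold lower number (0.05 log units; within the scatter) from compound 1 to compound 2 and a 1.0-fold higher number (0.01 log units; within the scatter) from compound 3 to compound 4, 1.1-fold (0.06 log units) apart, within the scatter of two such steps. Within the data shown here, this shows that the change carried over without a step beyond the scatter in these two pairs, but it does not show that the same would hold on a further core or in any other read-out, and with only two pairs, which differ both in core and in where the fluoro sits, the effects of core and place cannot be separated.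

From the compounds shown here alone, whether other groups in the same place, such as chloro, trifluoromethyl, nitrile or hydroxyl, would also stay within the scatter remains open. Also open is what the amine of compound 3 and compound 4 contributes compared with the acetamide of compound 1 and compound 2, since no pair shown differs in that one place alone.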